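The compounds below may be only part of what the source reports. "The series", "measured", "known", "first", "only" and "open" are said of these compounds alone.

Measured so far:
compound 1 `O=C(O)/C=C/c1ccc(/C(=C(\c2ccccc2)C(F)F)c2ccc3[nH]ncc3c2)cc1`: 14 nM
compound 2 `CC(C)/C(=C(/c1ccc(/C=C/C(=O)O)cc1)c1ccc2[nH]ncc2c1)c1ccccc1`: 4 nM
compound 3 `CC/C(=C(/c1ccc(/C=C/C(=O)O)cc1)c1ccc2[nH]ncc2c1C)c1ccccc1`: 50 nM

In a functional assay on MCF7 cells (Homo sapiens) for cytotoxicity, read by CellTiter-Glo, with a stated time of 5 days (a higher number here means a weaker inhibitor, a lower number a stronger inhibitor), compound 3 stands highest of the three numbers; compound 1 is nearest to it and compound 2 furthest, both beyond the scatter. Within the data shown here, the single measured step, a 3.5-fold lower number from compound 1 to compound 2 (0.54 log units; beyond the scatter), concerns a different group and does not bear on the change now in question. Compound 4 `CC/C(=C(/c1ccc(/C=C/C(=O)O)cc1)c1cc(Cl)c2[nH]ncc2c1)c1ccccc1` differs from compound 3 in one place: 7-chloro-1H-indazol-5-yl in place of 4-methyl-1H-indazol-5-yl on a double-bonded chain carbon bound to an aromatic carbon and a double-bonded chain carbon. Among the measured compounds shown here, no measured pair tests this exchange, so its direction is open; the numbers only show that the two compounds without a substituted indazolyl group sit lower than compound 3. Compound 4 is therefore expected near 20 nM, in the range 5 nM to 80 nM, an expected step of a 2.5-fold lower number from compound 3 to compound 4 (0.40 log units; beyond the scatter).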

Compound 4, half-maximal inhibitory concentration: 56 nM
Compound 4: middle estimate off by 2.8-fold (0.45 log units), on the low side; low and high end bracket the measured number.
By their numbers in this assay, from the lowest: compound 2; then compound 1; then compounds 3 and 4 (each within the scatter of the next).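

In this assay, 7-chloro-1H-indazol-5-yl in place of 4-methyl-1H-indazol-5-yl gives a 1.1-fold higher number from compound 3 to compound 4 (0.05 log units; within the scatter), so this assay does not separate the two substituted indazolyl groups. Among these compounds, this pair gives the series its only direct reading of a change in the indazolyl group, and the exchange leaves the number unchanged within the scatter. No available evidence bears on this result. As far as these compounds go, how the unsubstituted 1H-indazol-5-yl group compares on the otherwise identical background remains open. So does the effect of a methoxy group or an amine on the indazolyl group.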